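The source may hold more compounds than are shown below. What is called first, only, known or untested is meant among the compounds shown, and "the series" means these compounds.

Measured in a functional assay on HCT-116 cells (Homo sapiens) for antiproliferative activity, with a stated time of 72 h; on this read-out higher numbers stand for weaker inhibition and lower numbers for stronger inhibition:
- compound 1 `Nc1ncnn2c([C@@H]3O[C@H](CO)[C@@H](O)[C@H]3O)cc(-c3ccc(F)cc3F)c12`: 59500 nM
- compound 2 `Nc1ncnn2c([C@@H]3O[C@H](CO)[C@@H](O)[C@H]3O)cc(/C=C/c3ccccc3)c12`: 4800 nM

Of these two compounds, compound 2 has the lower number, at 4800 nM, and so shows the stronger inhibition in this assay. The gap to compound 1 lies beyond the scatter.

The next compound to be tested is compound 3 `Nc1ncnn2c([C@@H]3O[C@H](CO)[C@@H](O)[C@H]3O)cc(-c3ccccc3Cl)c12`, in which 2-chlorophenyl takes the place of 2-phenylethenyl on an aromatic carbon: 2-chlorophenyl in place of 2-phenylethenyl on an aromatic carbon.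

Among the compounds with values here, only one measured step bears on this change: a 12-fold lower number from compound 1 to compound 2 (1.09 log units; beyond the scatter). That step is large, and it put 2-phenylethenyl in place of 2,4-difluorophenyl at the same place. Within the data shown here, compound 3 reverses the kind of change, again setting a substituted phenyl there, though no measured compound carries 2-chlorophenyl itself. A rise in the number is therefore expected, probably somewhat smaller than the measured step but still beyond the scatter.

The estimated change is a 5.2-fold higher number from compound 2 to compound 3 (0.72 log units; beyond the scatter).

For compound 3 the expected value is 25000 nM, with an estimated range from 8000 nM to 70000 nM.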

Compound 3, half-maximal inhibitory concentration: > 100000 nM
Compound 3: only a limit was reported; the forecaster's own chance of this, stated with the estimate: 10%; at least 4.0-fold (0.60 log units) between middle value and limit.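

In this assay, compound 3 gives only a limit and not a number: the limit of > 100000 nM in this assay, at which 1 of the 3 values shown sits.

Even so, the step is large and beyond the scatter at its floor, an at least 20-fold higher number from compound 2 to compound 3 (1.31 log units; beyond the scatter), so 2-phenylethenyl at this place now stands apart from a second halogen-bearing phenyl group, 2-chlorophenyl, and not only from 2,4-difluorophenyl. The two halogen-bearing phenyl groups cannot be put in order, since the step between them, an at least 1.6-fold higher number from compound 1 to compound 3 (0.22 log units; that floor lies within the scatter), does not separate them.

The compounds shown leave open whether the double bond outside the aromatic ring matters for the lower number of compound 2, or whether a saturated 2-phenylethyl group or an unsubstituted phenyl would serve as well. Also open, from the compounds shown here alone, are how an amine or a carboxylic acid on the phenyl ring of 2-phenylethenyl would read in this assay, and where the true value of compound 3 lies beyond its limit.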